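The compounds below may be only part of what the source reports. "The series", "measured", "known", "first", "only" and "open" are said of these compounds alone.

Measured so far:
- compound 1 `Nc1ccc(CN2N=C(c3ccc(F)cc3)C3C=CC=CC3C2=O)cc1` — > 80000 nM
- compound 2 `CN(C)CCCCN(C(=O)O)c1ccccc1Cn1nc(-c2ccc(F)cc2)c2ccccc2c1=O` — 48500 nM
- compound 3 `CN(C)CCCCN(C(=O)O)c1ccc(N2N=C(c3ccc(F)cc3)C3C=CC=CC3C2=O)cc1` — 21800 nM

In an ADME assay on Huh-7 cells (Homo sapiens) for cytotoxicity, read by MTT assay, with a stated time of 48 h (on this read-out higher numbers stand for lower toxicity in this test and lower numbers for higher toxicity in this test), compound 1 stands only at a limit: its value of > 80000 nM is a limit of the assay and not a number, as noted in the limit of > 80000 nM in this assay, at which 1 of the 3 values shown sits. Compound 2 gives 48500 nM in this assay, and compound 3 gives 21800 nM; both carry a dimethylaminobutyl chain on a nitrogen attached to an aromatic ring and both return a number rather than a limit.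

Compound 4 `CN(C)CCCCNC(=O)Nc1ccc(CN2N=C(c3ccc(F)cc3)C3C=CC=CC3C2=O)cc1` is not yet measured. It differs from compound 1 by one change: (4-(dimethylamino)butyl)carbamoyl in place of hydrogen on a nitrogen on an aromatic ring. Going by the values given here, no step between two measured compounds matches this change, so its size is not known. Compound 4 is expected to fall somewhat lower than compound 1, in the region where compound 2 with 48500 nM and compound 3 with 21800 nM sit, with the step of an at least 2.0-fold lower number from compound 1 to compound 4 (0.30 log units; that floor lies within the scatter) expected to be modest. The estimate for compound 4 in this assay is 40000 nM, expected between 15000 nM and 100000 nM.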

Compound 4, half-maximal cytotoxic concentration: 46600 nM
Compound 4: middle estimate off by 1.2-fold (0.07 log units), on the low side, within the range that was stated.
By their numbers in this assay, from the lowest: compound 3; then compounds 4 and 2 (each within the scatter of the next). At a limit, above all of these: compound 1.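

In this assay, compound 1 gives > 80000 nM, which is a limit of the assay and not a number. The nitrogen on an aromatic ring now has its first readable step, as (4-(dimethylamino)butyl)carbamoyl in place of hydrogen gives an at least 1.7-fold lower number from compound 1 to compound 4 (0.23 log units; that floor lies within the scatter). Compound 4 returns a number, 46600 nM. The step has only a floor, so its true size remains unknown and the data do not place it beyond the scatter: the limit of > 80000 nM in this assay, at which 1 of the 4 values shown sits.

The compounds shown leave open how a shorter or longer chain, or a primary amine or carboxylic acid at the chain end in place of dimethylamino, would read in this assay. They also leave open whether a plain acetyl group on the same nitrogen, without the chain, would give a number or a limit.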